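Working notes on a cytotoxicity series, compound 4 pending

The compounds below may be only part of what the source reports. "The series", "measured", "known", "first", "only" and "open" are said of these compounds alone.

Compound 1 `COc1cc2c(cc1OC)CN(S(=O)(=O)c1ccc(-n3cc(COc4ccccc4C(C)=O)nn3)cc1)CC2` sits at the limit > 50 ug/mL in a functional assay on A549 cells (Homo sapiens) for cytotoxicity, read by MTT assay, with a stated time of 48 h; on this read-out lower numbers stand for stronger inhibition and higher numbers for weaker inhibition.
Compound 2 `COc1cc2c(cc1OC)CN(S(=O)(=O)c1ccc(-n3cc(COc4ccc5ccccc5c4)nn3)cc1)CC2` sits at the limit > 50 ug/mL in this assay.
Compound 3 `O=S(=O)(c1ccc(-n2cc(COc3ccccc3)nn2)cc1)N1CCc2ccccc2C1` sits at the limit > 50 ug/mL in this assay.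

None of the three measured values is a number: all three sit at the same limit, (the limit of > 50 ug/mL in this assay, at which 3 of the 3 values shown sit). Compound 2 therefore stands only at a limit in this assay, with no number shown for it. Among the compounds with values here, the one single-site step among the measured compounds, a step that the two limits leave unreadable from compound 1 to compound 2, is left unreadable by the two limits, so its size is unknown. Compound 4 `COc1cc2c(cc1OC)CN(S(=O)(=O)c1ccc(-n3cc(COc4ccccc4)nn3)cc1)CC2` differs from compound 2 by phenyl in place of naphthalen-2-yl on an oxygen on a saturated carbon. Within the data shown here, the step from compound 1 to compound 2 also alters the group on that oxygen, but it bears no readable size, so no measured step gives a size for the change to compound 4. Compound 3 carries the same phenoxy group and also sits at the limit in this assay. Compound 4 is expected to remain at the limit as well, with an estimate of 70 ug/mL and a range from 30 ug/mL to 200 ug/mL. The step that the limit leaves unreadable from compound 2 to compound 4 is expected to stay within the scatter.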

Compound 4, half-maximal inhibitory concentration: > 50 ug/mL
Compound 4: no number, only a limit; the forecaster's own chance of this, stated with the estimate: 85%; the middle value is on the limit's open side.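

Compound 4 adds no readable step, as its steps from compound 1 and compound 2 join limits rather than numbers in this assay: the limit of > 50 ug/mL in this assay, at which 4 of the 4 values shown sit.

The compounds shown leave open whether any group on that oxygen gives a measurable value in this assay.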